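Working notes: amide change from compound 2 to compound 4

A few compounds are considered here, and "the series" means these few. Any claim that something is new, unique, unknown or untested is made for them only; others in the source may bear on it.

Measured so far in a functional assay on HCT-116 cells (Homo sapiens) for antiproliferative activity, read by MTT assay, with a stated time of 72 h; on this read-out higher numbers stand for weaker inhibition and lower numbers for stronger inhibition:
compound 1 `O=C(CSc1cccc(O)c1)Nc1ccc2nc(NC(=O)c3ccc(F)cc3)sc2c1` — 6170 nM
compound 2 `O=C(CSc1ccc(Cl)cc1)Nc1ccc2nc(NC(=O)c3ccc(F)cc3)sc2c1` — 1360 nM
compound 3 `O=C(CSc1ncccn1)Nc1ccc2nc(NC(=O)c3ccc(C(F)(F)F)cc3)sc2c1` — 2220 nM

Compound 2 holds the lowest of the three numbers, though compound 3 stays within the scatter of it. Among the measured compounds shown here, the only single-point step, a 4.5-fold lower number from compound 1 to compound 2 (0.66 log units; beyond the scatter), is a change on the sulfur and says nothing about the amide carbonyl. Compound 4 `CCCC(=O)Nc1nc2ccc(NC(=O)CSc3ccc(Cl)cc3)cc2s1` differs from compound 2 by propyl in place of 4-fluorophenyl on a carbonyl carbon. Compound 3 differs from compound 2 in two places, so its value shows no clean comparison. For the measured compounds named here, no measured step bears on this change, and the expectation is therefore weak. Compound 4 is expected to give 3000 nM, in the range 1000 nM to 10000 nM. The step of a 2.2-fold higher number from compound 2 to compound 4 (0.34 log units; beyond the scatter) is thus expected to be modest, a higher number.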

Compound 4, half-maximal inhibitory concentration: 2120 nM
Compound 4: the middle estimate sits 1.4-fold (0.15 log units) above what was measured, and the stated range covers the measured number.
By their numbers in this assay, from the lowest: compounds 2, 4 and 3 (each within the scatter of the next); then compound 1.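

In this assay, among the compounds shown here, propyl in place of 4-fluorophenyl on a carbonyl carbon gives a 1.6-fold higher number from compound 2 to compound 4 (0.19 log units; within the scatter), the first reading at this position. With 4-chlorophenyl on the sulfur, the aromatic ring on this carbonyl carbon is therefore not needed for a value in this range. Nothing at hand accounts for this result.

From the compounds shown here alone, whether a longer chain, a cyclohexyl ring or an amine on this carbonyl carbon stays in the same range remains open. Also open, going by these compounds, is whether propyl reads the same with 3-hydroxyphenyl on the sulfur.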